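Cytotoxicity Limits and a Pyrrolidin-2-yl Replacement

The compounds below may be only part of what the source reports. "The series", "measured", "known", "first", "only" and "open" are said of these compounds alone.

Compound 1 `O=C(NCCCCO)Nc1nc2ccc(C(=O)c3ccccc3)cc2[nH]1`: > 30000 nM
Compound 2 `CN1CCC(CCn2c(N)nc3ccc(C(=O)c4ccccc4)cc32)CC1`: > 30000 nM

In an ADME assay on HL-60 cells (Homo sapiens) for cytotoxicity, read by resazurin assay, with a stated time of 72 h (on this read-out lower numbers stand for an effect already at smaller amounts and higher numbers for an effect only at larger amounts of compound), compound 1 reaches only a limit, > 30000 nM. Compound 2 likewise stands at a limit, > 30000 nM. Among the measured compounds shown here, both measured values sit at the limit of > 30000 nM in this assay, at which 2 of the 2 values shown sit, so compound 2 is level with the one other compound and no step between them can be sized. Compound 3 `Nc1nc2ccc(C(=O)c3ccccc3)cc2n1C[C@@H]1CCCN1` differs from compound 2 by pyrrolidin-2-yl in place of (1-methylpiperidin-4-yl)methyl on a saturated chain carbon bound to an aromatic nitrogen. For the measured compounds named here, with no measured step to draw on, the change is expected to bring nothing beyond the scatter, and compound 3 is expected near 30000 nM, within 10000 nM to 100000 nM, most probably again reported as a limit. The expected step is a number no higher from compound 2 to compound 3 (the limit leaves the size open).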

Compound 3, half-maximal effective concentration: > 30000 nM
Compound 3: only a limit was reported; the forecaster's own chance of this, stated with the estimate: 80%; the middle value sits exactly at the limit.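

Among the compounds shown here, compound 2 and compound 3 both end at a limit, so no step between them can be read: the limit of > 30000 nM in this assay, at which 3 of the 3 values shown sit. The compounds shown leave open how far pyrrolidin-2-yl in place of (1-methylpiperidin-4-yl)methyl shifts the half-maximal effective concentration, and which change to the shared core would bring a readable value.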